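Swapping methoxy for methyl on the iodo compound

The compounds below may be only part of what the source reports. "The series", "measured", "known", "first", "only" and "open" are said of these compounds alone.

Measured in a functional assay on SW480 cells (Homo sapiens) for cytotoxicity, read by MTT assay, with stated times of 3 h and 24 h; a higher number here means a weaker inhibitor, a lower number a stronger inhibitor:
- compound 1 `COc1ccc(C2=[N+]3C(=Nc4c(-c5ccccc5)c5c(n4[B-]3(F)F)-c3ccc(OC)cc3CC5)C(c3ccccc3)=C2Br)cc1` gives 1900 nM
- compound 2 `COc1ccc2c(c1)CCc1c(-c3ccccc3)c3n(c1-2)[B-](F)(F)[N+]1=C(c2ccc(C)cc2)C(Br)=C(c2ccccc2)C1=N3` gives 15600 nM
- compound 3 `COc1ccc(C2=[N+]3C(=Nc4c(-c5ccccc5)c5c(n4[B-]3(F)F)-c3ccc(OC)cc3CC5)C(c3ccccc3)=C2I)cc1` gives 120 nM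

Compound 3 has the lowest number of the three, beyond the scatter from both others. Compound 4 `COc1ccc2c(c1)CCc1c(-c3ccccc3)c3n(c1-2)[B-](F)(F)[N+]1=C(c2ccc(C)cc2)C(I)=C(c2ccccc2)C1=N3` keeps its iodo group but has methyl in place of methoxy, turning 4-methoxyphenyl into 4-methylphenyl (methyl in place of methoxy on an aromatic carbon). The same swap, made with bromo in the molecule, gave an 8.2-fold higher number from compound 1 to compound 2 (0.91 log units; beyond the scatter). Exchanging bromo for iodo gave a 16-fold lower number from compound 1 to compound 3 (1.20 log units; beyond the scatter), so iodo may carry a similar gain without the methoxy group. That swap has been measured only once, so a similar upward step in this assay is only an expectation. The estimated step is a 7.5-fold higher number from compound 3 to compound 4 (0.88 log units; beyond the scatter). For compound 4 the estimated value is 900 nM, with an expected range of 250 nM to 3500 nM.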

Compound 4, half-maximal inhibitory concentration: 660 nM
Compound 4: middle estimate off by 1.4-fold (0.13 log units), on the high side, and the stated range covers the measured number.
By their numbers in this assay, from the lowest: compound 3; then compound 4; then compound 1; then compound 2.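

In this assay, the swap gives a 5.5-fold higher number from compound 3 to compound 4 (0.74 log units; beyond the scatter) even with iodo in the molecule, so the loss on leaving methoxy for methyl is not confined to the bromo compounds, and its size carries over: the same change on two cores in this assay, an 8.2-fold higher number (0.91 log units; beyond the scatter) from compound 1 to compound 2 and a 5.5-fold higher number (0.74 log units; beyond the scatter) from compound 3 to compound 4, 1.5-fold (0.17 log units) apart, within the scatter of two such steps. The halogen change likewise holds up without the methoxy group, giving a 24-fold lower number from compound 2 to compound 4 (1.37 log units; beyond the scatter) and matching its earlier counterpart: the same change on two cores in this assay, a 16-fold lower number (1.20 log units; beyond the scatter) from compound 1 to compound 3 and a 24-fold lower number (1.37 log units; beyond the scatter) from compound 2 to compound 4, 1.5-fold (0.17 log units) apart, within the scatter of two such steps. Across these four compounds, the two changes behave as separate, roughly constant steps.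

Still open, going by these compounds, is how an amine or a carboxylic acid at this ring position would compare with methoxy.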